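Toward a nitrogen-bearing ring on the ether oxygen

This account rests on a few compounds, and the source may have more. Where it says the series, first, only, none or still open, it means among the compounds named here.

Compound 1 `Cc1ccc([C@@H](C)Oc2cc3oc(=O)n(CCC(=O)O)c3cc2Cl)nc1`: 3.16 nM
Compound 2 `O=C(O)CCn1c(=O)oc2cc(OCC3CCC3)c(Cl)cc21`: 25.1 nM

Of the compounds shown here, two have been measured in an assay for inhibition of kynurenine 3-monooxygenase (Homo sapiens), read by mass spectrometry, with a stated time of 1 h; a higher number here means a weaker inhibitor, a lower number a stronger inhibitor. Compound 1 gives 3.16 nM, and compound 2 gives 25.1 nM, so compound 2 stands as the higher of the two numbers, the weaker inhibitor, with a gap to compound 1 that lies beyond the usual scatter.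

Compound 3 `C[C@@H](Oc1cc2oc(=O)n(CCC(=O)O)c2cc1Cl)c1cccnn1` has not yet been measured. It is derived from compound 2 by one change: a group of 8 heavy atoms (6 carbon, 2 nitrogen; one six-membered aromatic ring with 2 hetero atoms) in place of a group of 5 heavy atoms (5 carbon; one four-membered non-aromatic ring of carbon only), on an oxygen on an aromatic ring. Both compounds keep the same shared core, and the change concerns only what hangs on that oxygen.

Among the compounds with values here, no step between measured compounds tells directly what this exchange does. Still, compound 1 also carries a different group on that oxygen and gives 3.16 nM, which suggests that a group of this kind can go with a lower number. Compound 3 is therefore expected to move down in this assay, by a step of a 4.2-fold lower number from compound 2 to compound 3 (0.62 log units; beyond the scatter). The estimate for compound 3 is 6 nM, with a range from 2 nM to 20 nM.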

Compound 3, half-maximal inhibitory concentration: 1.26 nM
Compound 3: the middle estimate sits 4.8-fold (0.68 log units) above what was measured; measured number below the stated range.
By their numbers in this assay, from the lowest: compound 3; then compound 1; then compound 2.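

In this assay, within the data shown here, replacing cyclobutylmethyl on the oxygen with the group that carries a pyridazin-3-yl ring gives a 20-fold lower number from compound 2 to compound 3 (1.30 log units; beyond the scatter) and is the first direct reading of a change at this position. It shows that what hangs on this oxygen can shift the number by a large step while the shared core stays the same. The ring at the end of the group also counts, since pyridazin-3-yl in place of 5-methylpyridin-2-yl gives a 2.5-fold lower number from compound 1 to compound 3 (0.40 log units; beyond the scatter) and leaves compound 3 with the lowest number of the three, so this ring with two hetero atoms goes with a stronger inhibitor here, though nothing shown explains why either step occurs.

The compounds shown leave open how much of the smaller step belongs to the methyl group and how much to the ring nitrogens, and a plain pyridin-2-yl group on the same chain carbon would separate the two. Also open is what the defined stereocentre contributes, since neither its mirror-image form nor a pyridazin-3-ylmethyl group appears among these compounds.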